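A few compounds are considered here, and "the series" means these few. Any claim that something is new, unique, unknown or untested is made for them only; others in the source may bear on it.

Compound 1 `O=C1Nc2ccc(Br)cc2/C1=C/c1cccc(OCc2cn(Cc3ccccc3)nn2)c1` gives in a functional assay on HeLa cells (Homo sapiens) for inhibition, read by MTT assay, with a stated time of 48 h (a higher number here means a weaker inhibitor, a lower number a stronger inhibitor), a reading of > 50000 nM, which is a limit of the assay rather than a number. Compound 2 `O=C1Nc2ccc([N+](=O)[O-])cc2/C1=C\c1cccc(OCc2cn(Cc3ccccc3)nn2)c1` likewise returns > 50000 nM, again a limit. Where compound 1 stands therefore cannot be fixed: the limit of > 50000 nM in this assay, at which 2 of the 2 values shown sit, so no measured step within the series exists. Compound 3 `COc1ccc(Cc2ccc3c(c2)/C(=C/c2cccc(OCc4cn(Cc5ccccc5)nn4)c2)C(=O)N3)cc1` carries 4-methoxybenzyl in place of bromo on an aromatic carbon, the 4-methoxybenzyl in place of bromo on an aromatic carbon. With both measured values at a limit, no direction is supported, and the expected step of a number no higher from compound 1 to compound 3 (the limit leaves the size open) is taken as none beyond the scatter. Compound 3 is accordingly expected near 50000 nM, within 10000 nM to 200000 nM, most probably reported only as a limit.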

Compound 3, half-maximal inhibitory concentration: 7700 nM
Beside the measured number, compound 3's estimate is 6.5-fold (0.81 log units) above it, and the stated range ends above it.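

Setting 4-methoxybenzyl in place of bromo on this aromatic carbon gives an at least 6.4-fold lower number from compound 1 to compound 3 (0.81 log units; beyond the scatter) in this assay. Going by these compounds alone, this position of the shared core therefore accepts a much larger group carrying its own aromatic ring, and the change yields the first reading that is a number rather than a limit. The true size of the step stays open, since compound 1 gives only a limit: the limit of > 50000 nM in this assay, at which 2 of the 3 values shown sit.

Which part of the 4-methoxybenzyl group matters remains open, the ring or the methoxy oxygen. Plain benzyl, an amine or a carboxylic acid at this carbon would help separate these.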